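The compounds below may be only part of what the source reports. "The series", "measured", "known", "first", "only" and "open" are said of these compounds alone.

Compound 1 `CN(CC1CCN(CCCc2c[nH]c3ccc(-n4cnnc4)cc23)CC1)C(=O)Nc1ccccc1` and compound 2 `O[C@@H]1Cc2ccccc2[C@H]1NC1CCN(CCCc2c[nH]c3ccc(-n4cnnc4)cc23)CC1` share a common core and were both examined in an assay on CHO cells for displacement of a labelled ligand from 5-hydroxytryptamine receptor 1B (Homo sapiens); a lower number here means a stronger inhibitor, a higher number a weaker inhibitor. Compound 1 gives 6.2 nM, while compound 2 gives 210 nM. Of the two numbers available, compound 2 stands at the higher one, and the gap down to compound 1 lies beyond the usual scatter of this assay, so compound 2 is the weaker of the pair as far as these two measurements go. Among the measured compounds shown here, no other measured pairs are available to show how single changes on the amine nitrogen move the number.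

Compound 3 `c1cncc(CNC2CCN(CCCc3c[nH]c4ccc(-n5cnnc5)cc34)CC2)c1` is a variation on compound 2. The change between them is (pyridin-3-yl)methyl in place of 2-hydroxy-2,3-dihydro-1H-inden-1-yl on an amine nitrogen: a smaller group, with no hydrogen-bond donor and no defined stereocentres, takes the place of the larger bicyclic one on the amine nitrogen whose other neighbour is a saturated ring carbon.

With nothing measured on this kind of exchange, the expectation for compound 3 is a step of a 1.8-fold lower number from compound 2 to compound 3 (0.24 log units; within the scatter) that is modest and most likely within the scatter, with a slight lean toward a lower number. Compound 3 is therefore estimated at 120 nM, with a plausible range from 25 nM to 600 nM.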

Compound 3, half-maximal inhibitory concentration: 140 nM
Estimate against measurement, compound 3: 1.2-fold (0.07 log units) below, within the range that was stated.
By their numbers in this assay, from the lowest: compound 1; then compounds 3 and 2 (each within the scatter of the next).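

In this assay, putting (pyridin-3-yl)methyl in place of 2-hydroxy-2,3-dihydro-1H-inden-1-yl on the amine nitrogen gives a 1.5-fold lower number from compound 2 to compound 3 (0.18 log units; within the scatter), the first single-place step seen at this position. The exchange removes the hydrogen-bond donor and the defined stereocentres of the leaving group, yet the number stays within the scatter, so neither feature is shown here to be required for a value of this size. Nothing at hand explains why the two groups read alike in this assay.

The compounds shown leave open whether the ring nitrogen of the entering group has any bearing on the number, which a plain benzyl group on the same amine nitrogen would test, and whether the hydroxyl matters by itself, which the 2,3-dihydro-1H-inden-1-yl group without it would test. Among the compounds shown here, they also leave open how either group relates to the substituent of compound 1, as no single-place step links that compound to compound 2 or compound 3.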